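From Hydroxy to Chloro: Expecting Little Change in Growth Inhibition

The source may hold more compounds than are shown below. What is called first, only, known or untested is meant among the compounds shown, and "the series" means these compounds.

Going by the values given here, compound 2 `O=C(/C=C/c1cc2ccccc2[nH]c1=O)c1ccc(O)cc1` is one of only two compounds tested so far in a functional assay on SNB-19 cells (Homo sapiens) for cytotoxicity, read by sulforhodamine B assay, with a stated time of 24 h (on this read-out higher numbers stand for weaker inhibition of growth and lower numbers for stronger inhibition of growth), where compound 2 gives 4590 nM. Its companion, compound 1 `COc1ccc(C(=O)/C=C/c2cc3ccccc3[nH]c2=O)cc1`, gives 4200 nM in this assay. The two stand at the same level: the gap between them, a 1.1-fold higher number from compound 1 to compound 2 (0.04 log units; within the scatter), lies within the scatter, so neither can be called more or less active than the other.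

Compound 3 `O=C(/C=C/c1cc2ccccc2[nH]c1=O)c1ccc(Cl)cc1` has not yet been measured. It differs from compound 2 by chloro in place of hydroxy on an aromatic carbon: the hydroxy leaves and a chloro enters on an aromatic carbon of a six-membered aromatic ring of carbon only, para to a large group; cut one bond further out, the change reads 4-hydroxyphenyl to 4-chlorophenyl.

Among the compounds with values here, only one measured step touches this position, the exchange of methyl for hydrogen on its oxygen, which gave a 1.1-fold higher number from compound 1 to compound 2 (0.04 log units; within the scatter), within the scatter. Within the data shown here, no measured pair swaps hydroxy for chloro, so the expectation rests on thin ground, and the estimated step of a 1.0-fold lower number from compound 2 to compound 3 (0.01 log units; within the scatter) is set close to nothing with a wide range. Compound 3 is expected to give 4500 nM in this assay, with a range from 1500 nM to 13000 nM.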

Compound 3, concentration for 50% growth inhibition: 5110 nM
The estimate for compound 3 lay 1.1-fold (0.06 log units) below the measured number; measured number inside the range.
By their numbers in this assay, from the lowest: compounds 1, 2 and 3 (each within the scatter of the next).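

In this assay, this position on the six-membered aromatic ring of carbon only has now carried a group not attached through oxygen, and the numbers still stay within the scatter: the exchange of hydroxy for chloro gives a 1.1-fold higher number from compound 2 to compound 3 (0.05 log units; within the scatter), and the exchange of methoxy for chloro gives a 1.2-fold higher number from compound 1 to compound 3 (0.09 log units; within the scatter). Hydroxy counts 1 hydrogen-bond donor and 1 hydrogen-bond acceptor while chloro counts 0 of each, so across compound 2 and compound 3 this difference in the counts comes with no change in growth inhibition that can be told from the scatter. Nothing at hand explains why these three groups read alike.

Still open is whether this position stays as indifferent with an amine, a carboxylic acid or a longer chain such as butoxy, since all three groups shown are single atoms or small oxygen-linked groups. Also open, from the compounds shown here alone, is whether the same flat picture would hold on other cell lines, or for changes made elsewhere on the shared core.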